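Branching a chain on the amide of compound 3

The source may report more compounds than this note shows. Statements on the series, on what has been measured and on what is new or still open speak of the compounds shown alone.

Measured so far in a functional assay on NCI-H1975 cells (Homo sapiens) for antiproliferative activity, read by CCK-8 assay, with a stated time of 72 h; a higher number here means a weaker inhibitor of growth, a lower number a stronger inhibitor of growth:
compound 1, `CCC1C(=O)N(C)c2cnc(Nc3ccc(S(=O)(=O)NCC(C)C)cc3)nc2N1c1ccn(C)n1`, 15000 nM
compound 2, `CCCCNS(=O)(=O)c1ccc(Nc2ncc3c(n2)N(c2ccn(C)n2)C(CC)C(=O)N3C)cc1`, 4120 nM
compound 3, `CCCCNC(=O)c1ccc2c(ccn2-c2ncc3c(n2)N(C2CCCC2)[C@H](CC)C(=O)N3C)c1`, 990 nM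

Compound 3 gives the lowest of the three numbers in this assay; compound 2 sits nearest to it and compound 1 furthest. How the cores of compound 2 and compound 3 differ is not broken down here. Between compound 2 and compound 1 the single change is isopropyl in place of propyl on a saturated chain carbon bound to a sulfonamide nitrogen, and it produced a 3.6-fold higher number from compound 2 to compound 1 (0.56 log units; beyond the scatter).

Compound 4, `CC[C@@H]1C(=O)N(C)c2cnc(-n3ccc4cc(C(=O)NCC(C)C)ccc43)nc2N1C1CCCC1`, has not yet been measured in this assay. It differs from compound 3 by isopropyl in place of propyl on a saturated chain carbon bound to an amide-type nitrogen. This is the same kind of change as that from compound 2 to compound 1, but not the same: in the earlier pair the carbon is bound to a sulfonamide nitrogen, here to an amide-type nitrogen, and the cores differ as well. Resting on the one shown step, compound 4 is expected to show a 2.5-fold higher number from compound 3 to compound 4 (0.40 log units; beyond the scatter) in this assay, a rise of similar size. Compound 4 is estimated at 2500 nM, with a likely range from 900 nM to 7000 nM.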

Compound 4, concentration for 50% growth inhibition: "not active" (no number reported)
Nothing numeric was reported for compound 4; the estimate stays without a comparison.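

In this assay, within the data shown here, compound 4 was reported only as "not active", without a number, so no step from compound 3 to compound 4 can be read. The compounds shown leave open how far butyl to isobutyl on this amide moves the number. No supporting data bear on this result.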